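The source may report more compounds than this note shows. Statements on the series, on what has been measured and on what is new or still open speak of the compounds shown alone.

Three compounds sharing one core, each with a long saturated chain, have been tested in a functional assay on MCF7 cells (Homo sapiens) for antiproliferative activity, read by MTT assay, with a stated time of 48 h; on this read-out higher numbers stand for weaker inhibition and lower numbers for stronger inhibition. Compound 2 `CCCCCCCCn1cc(COC[C@@H]2OC[C@H](N)[C@H]2O)nn1` gives > 128000 nM, which is a limit of the assay and not a number. Compound 3 `CCCCCCCCCCn1cc(COC[C@@H]2OC[C@H](N)[C@H]2O)nn1`, with a longer chain, gives 45000 nM, the higher of the two actual numbers. Compound 1 `CCCCCCCCCCCCn1cc(COC[C@@H]2OC[C@H](N)[C@@H]2O)nn1` stands lower at 2210 nM, but its core differs in the spatial arrangement at the carbon carrying the hydroxyl.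

Compound 4 `CCCCCCCCCCCCn1cc(COC[C@@H]2OC[C@H](N)[C@H]2O)nn1` extends the chain of compound 3 and keeps its core: ethyl in place of hydrogen on a saturated chain carbon, ten or more bonds along the chain from an aromatic nitrogen. The same kind of change has been measured once, as an at least 2.8-fold lower number from compound 2 to compound 3 (0.45 log units; beyond the scatter). That size is only a floor because of the limit of > 128000 nM in this assay, at which 1 of the 3 values shown sits. Compound 4 shares its chain with compound 1, though not the same core arrangement, so compound 1 at 2210 nM is only a loose guide to how low this chain length can go.

Resting on these two points, a further step beyond the scatter is expected in this assay, towards a lower number, and the expected size is a 4.5-fold lower number from compound 3 to compound 4 (0.65 log units; beyond the scatter). The estimate for compound 4 is 10000 nM, with an expected range of 3000 nM to 35000 nM.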

Compound 4, half-maximal inhibitory concentration: 2620 nM
The estimate for compound 4 lay 3.8-fold (0.58 log units) above the measured number; measured number below the stated range.
By their numbers in this assay, from the lowest: compounds 1 and 4 (each within the scatter of the next); then compound 3. At a limit, above all of these: compound 2.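

In this assay, ethyl in place of hydrogen on a saturated chain carbon, ten or more bonds along the chain from an aromatic nitrogen, gives a 17-fold lower number from compound 3 to compound 4 (1.23 log units; beyond the scatter), a large step, and butyl in place of hydrogen gives an at least 48-fold lower number from compound 2 to compound 4 (1.68 log units; beyond the scatter). Compound 2 stands at a limit and not at a number, so the size of that second step is only a floor: the limit of > 128000 nM in this assay, at which 1 of the 4 values shown sits. Compound 4 also shows that, with this chain, the configuration drawn at one saturated ring carbon leaves the two numbers within the scatter, with a 1.2-fold higher number from compound 1 to compound 4 (0.07 log units; within the scatter): the fact that compounds 1 and 4 differ only in the configuration as drawn.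

Among these compounds, whether a longer chain than the one in compound 4 would lower the number further stays open, as does the point at which this trend along the chain would end. As far as these compounds go, the core of compound 1 appears here with only one chain, so it also stays open whether its configuration would make a difference with a shorter chain, such as those of compound 2 and compound 3.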